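Chain extension on the bromo compound: working notes

A few compounds are considered here, and "the series" means these few. Any claim that something is new, unique, unknown or untested is made for them only; others in the source may bear on it.

Values in a functional assay on SW480 cells (Homo sapiens) for antiproliferative activity, read by MTT assay, with a stated time of 48 h; on this read-out higher numbers stand for weaker inhibition and lower numbers for stronger inhibition:
- compound 1 `CCCCCCCC(CCO)n1cnc2c(Cl)ncnc21` gives 3630 nM
- compound 2 `CCCCCCCC(CCO)n1c(Br)nc2c(Cl)ncnc21` gives 14400 nM
- compound 3 `CCCCCCCCC(CCO)n1cnc2c(OC)ncnc21` gives 24600 nM
- compound 4 `CCCCCCCCCC(CCO)n1c(Br)nc2c(Cl)ncnc21` is not yet measured

Compound 2 at 14400 nM lies within the scatter of compound 3 at 24600 nM, so no order can be drawn between the two. Its gap to compound 1 is beyond the scatter. For the measured compounds named here, that gap is the only measured single change: a 4.0-fold higher number from compound 1 to compound 2 (0.60 log units; beyond the scatter), with bromo in place of hydrogen on an aromatic carbon.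

The change now in question is ethyl in place of hydrogen on a saturated chain carbon, eight bonds along the chain from an aromatic nitrogen. Going by the values given here, no measured step covers this change. The bromo step sits at another place in the structure, so it sets only a rough scale and gives no direction. Compound 3 differs from compound 2 in more than one place and cannot isolate the effect of the chain. With no evidence for a direction, no shift beyond the scatter is expected in this assay. The estimate is a 1.3-fold lower number from compound 2 to compound 4 (0.12 log units; within the scatter). For compound 4 the expected value is 11000 nM, with an expected range of 3500 nM to 32000 nM.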

Compound 4, half-maximal inhibitory concentration: 25000 nM
Compound 4: middle estimate off by 2.3-fold (0.36 log units), on the low side, and the stated range covers the measured number.
By their numbers in this assay, from the lowest: compound 1; then compounds 2, 3 and 4 (each within the scatter of the next).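

In this assay, ethyl in place of hydrogen on a saturated chain carbon, eight bonds along the chain from an aromatic nitrogen, gives a 1.7-fold higher number from compound 2 to compound 4 (0.24 log units; within the scatter) and so does not separate the two compounds. For the compounds shown here, this is the first reading of a change at this place in the chain, and on the bromo compound the position accepts the ethyl group with no difference that can be told from the scatter. Going by these compounds alone, the one step beyond the scatter is still a 4.0-fold higher number from compound 1 to compound 2 (0.60 log units; beyond the scatter) at another place in the structure, and no data at hand bear on the reason for either step.

As far as these compounds go, it remains open whether the ethyl change reads the same on the core of compound 1 without the bromo group, since a single step on a single core supports no rule for the chain. From the compounds shown here alone, it is also open whether a much longer chain, or an amine or a carboxylic acid at this same place, would move the number beyond the scatter in this assay or leave it where compound 2 and compound 4 stand.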